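The source may report more compounds than this note shows. Statements on the series, on what has been measured and on what is new or still open speak of the compounds shown alone.

Compound 1 (`O=C(NCc1ccc(F)cc1)c1c([N+](=O)[O-])noc1-c1ccc(Cl)cc1`) and compound 2 (`COc1cccc(CNC(=O)c2c([N+](=O)[O-])noc2-c2ccc(Cl)cc2)c1`) share one core and differ only in the phenyl group at the end of the amide side chain. In an ADME assay on J774.A1 cells (Mus musculus) for cytotoxicity, read by MTT assay, with a stated time of 48 h (a lower number here means that less compound is tolerated, a higher number that more compound is tolerated), compound 1 gives 91900 nM and compound 2 gives 68600 nM in the same test. These two values lie within the usual scatter of each other, so compound 2 stands level with compound 1 on the numbers available.

Compound 3 (`COc1cccc(CNC(=O)c2c([N+](=O)[O-])noc2-c2ccc(Cl)cc2Cl)c1`) keeps the side chain of compound 2 and alters the other aromatic ring. The change is chloro in place of hydrogen on an aromatic carbon and turns 4-chlorophenyl into 2,4-dichlorophenyl, with chloro in place of hydrogen on an aromatic carbon.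

For the measured compounds named here, the only measured step, a 1.3-fold lower number from compound 1 to compound 2 (0.13 log units; within the scatter) when 3-methoxyphenyl replaces 4-fluorophenyl, lies elsewhere in the molecule and stays small. Going by the values given here, no measured pair shows what this added chloro does, so this assay offers only weak guidance and no shift beyond the scatter is expected. The estimate is a 1.2-fold lower number from compound 2 to compound 3 (0.10 log units; within the scatter) for this step, an expected move that remains modest. For compound 3 the expected value is 55000 nM with an estimated range of 22000 nM to 110000 nM in this test.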

Compound 3, half-maximal cytotoxic concentration: 61200 nM
The estimate for compound 3 lay 1.1-fold (0.05 log units) below the measured number; the range from low to high includes it.
By their numbers in this assay, from the lowest: compounds 3, 2 and 1 (each within the scatter of the next).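

For the compounds shown here, this is the first measured change on the aromatic ring at the far end from the amide side chain, and it places a chloro group ortho to a large group and meta to a chloro group, turning 4-chlorophenyl into 2,4-dichlorophenyl. In this assay the step is small (a 1.1-fold lower number from compound 2 to compound 3 (0.05 log units; within the scatter)), so this one added chlorine atom leaves the tolerated concentration level with that of compound 2 on the numbers available. No measurement at hand speaks to the reason for this result.

As far as these compounds go, only chloro is seen at this position, so it remains open whether a larger or very different group there, such as an amine or a carboxylic acid, would also leave the number within the scatter. From the compounds shown here alone, the same addition is also seen with only the 3-methoxyphenyl side chain, so its size with the 4-fluorophenyl side chain of compound 1 remains unknown, as does the outcome of moving the chloro group to another place on the ring.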